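A Donor Removed: From Compound 2 to Compound 3

A few compounds are considered here, and "the series" means these few. Any claim that something is new, unique, unknown or untested is made for them only; others in the source may bear on it.

Measured compounds:
compound 1, `CC(C(=O)NCc1ccc(C(F)(F)F)cc1N1CCC(Cc2ccccc2)(N(C)C)CC1)c1ccc(NS(C)(=O)=O)c(F)c1`: "not active" (no number reported)
compound 2, `CN(C)C1(Cc2ccccc2)CCN(c2cc(C(F)(F)F)ccc2CNC(=O)Nc2cccc3c(=O)[nH]ccc23)CC1`: 43.7 nM

For the measured compounds named here, in an assay on CHO cells for agonist activity at transient receptor potential cation channel subfamily V member 1 (Homo sapiens), read by scintillation counting, with a stated time of 5 min, in the presence of a further agent that is not named here (a higher number here means that more compound is needed for the effect, a lower number that less compound is needed), compound 2 gives 43.7 nM, the only number in this set. Compound 1 is recorded in this assay as "not active" (no number reported), without a number. Compound 3, `CN(C)C1(Cc2ccccc2)CCN(c2cc(C(F)(F)F)ccc2CNC(=O)Nc2cccc3ncccc23)CC1`, remains to be measured. It differs from compound 2 by a group of 10 heavy atoms (9 carbon, 1 nitrogen; one six-membered aromatic ring of carbon only, one six-membered aromatic ring with 1 hetero atom) in place of a group of 11 heavy atoms (9 carbon, 1 nitrogen, 1 oxygen; one six-membered aromatic ring of carbon only, one six-membered aromatic ring with 1 hetero atom), on an amide-type nitrogen. Going by the values given here, no measured pair shows a change of this kind, so the size of the step is open. A modest weakening is expected, a step of about a 2.7-fold higher number from compound 2 to compound 3 (0.44 log units; beyond the scatter). Compound 3 is therefore estimated at 120 nM, within a range from 30 nM to 500 nM.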

Compound 3, half-maximal effective concentration: "not active" (no number reported)
For compound 3 the study gives words and no number; there is nothing to compare the estimate with.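

For the compounds shown here, compound 3 is recorded as "not active" (no number reported), so no step from compound 2 to compound 3 can be read. The compounds shown leave open the size of the change to quinolin-5-yl. No measurement here accounts for the result.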